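Sulfamate series: amine substituent and amide attachment

This account rests on a few compounds, and the source may have more. Where it says the series, first, only, none or still open, it means among the compounds named here.

Measured in an assay on HEK293 cells for inhibition of Steryl-sulfatase (Homo sapiens), tested at 0.1 uM; on this read-out higher numbers stand for a stronger effect at the one concentration tested and lower numbers for a weaker effect:
compound 1 `CCN(Cc1ccc(Br)cc1)c1cccc(C(=O)N2CCc3ccc(OS(N)(=O)=O)cc3C2)c1`: 24.2%
compound 2 `CCN(Cc1ccc(Br)cc1)c1ccc(C(=O)N2CCc3ccc(OS(N)(=O)=O)cc3C2)cc1`: 78.2%
compound 3 `CCN(Cc1ccncc1)c1ccc(C(=O)N2CCc3ccc(OS(N)(=O)=O)cc3C2)cc1`: 47%

Compound 1 and compound 2 hold the same atoms joined differently; the difference between the two cores is not broken down here, and compound 1 stands lowest of the three. From compound 2 to compound 3 the change is pyridin-4-yl in place of 4-bromophenyl on a saturated chain carbon bound to a nitrogen on an aromatic ring, and it gives a number 31.2 percentage points lower from compound 2 to compound 3 (beyond the scatter).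

Compound 4 `CCN(Cc1ccncc1)c1cccc(C(=O)N2CCc3ccc(OS(N)(=O)=O)cc3C2)c1` is not yet measured. It differs from compound 1 by pyridin-4-yl in place of 4-bromophenyl on a saturated chain carbon bound to a nitrogen on an aromatic ring, the same change at the same place as before, now made on the core of compound 1.

For compound 4 the expected step is a number 16.2 percentage points lower from compound 1 to compound 4 (beyond the scatter), because a number 31.2 percentage points lower from compound 2 to compound 3 (beyond the scatter) was large while compound 1 already gives only 24.2%, leaving little room downward. Compound 4 is therefore estimated at 8%, expected between 0% and 25%.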

Compound 4, a percentage reported as inhibition, at one concentration (the size of the read-out at that concentration, not a potency): 33.3%
Compound 4: the middle estimate sits 25.3 percentage points below what was measured, and the stated range ends below it.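

On the core of compound 1, pyridin-4-yl in place of 4-bromophenyl gives a number 9.1 percentage points higher from compound 1 to compound 4 (within the scatter) in this assay. The size of the step does not carry over from one core to the other: the same change on two cores in this assay, a number 31.2 percentage points lower (beyond the scatter) from compound 2 to compound 3 and a number 9.1 percentage points higher (within the scatter) from compound 1 to compound 4, 40.3 percentage points apart, beyond the scatter of two such steps. Going by these compounds alone, this rests on only two matched pairs read at a single concentration, so it shows that the step on one core cannot be assumed on the other, but it gives neither a general rule for the series nor a reason for the gap.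

The compounds shown leave open whether other groups in place of 4-bromophenyl, such as pyridin-3-yl or unsubstituted phenyl, also differ between the two cores. Also open, as far as these compounds go, is whether a longer chain in place of the ethyl on the amine nitrogen does so.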